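A few compounds are considered here, and "the series" means these few. Any claim that something is new, unique, unknown or untested is made for them only; others in the source may bear on it.

Series notes, shared core throughout. Among the measured compounds shown here, in a functional assay on HT cells (Homo sapiens) for antiproliferative activity, read by fluorescence, with a stated time of 72 h (on this read-out lower numbers stand for stronger inhibition of growth and higher numbers for weaker inhibition of growth), compound 1 `CC(C)c1n[nH]c2c(NCc3ccc(-c4ccccn4)cc3)nc(SC(CO)C(C)C)nc12` gives 980 nM, the highest of the three numbers so far, and its distance to each of the other two is beyond the scatter. Compound 2 `CC(C)c1n[nH]c2c(NCc3ccc(-c4ccccn4)cc3)nc(SC(C)C(C)O)nc12` gives 190 nM in this assay, and compound 3 `CC(C)c1n[nH]c2c(NCc3ccc(-c4ccccn4)cc3)nc(SCC(N)=O)nc12` gives 192 nM. The steps away from compound 1 are a 5.2-fold lower number from compound 1 to compound 2 (0.71 log units; beyond the scatter) and a 5.1-fold lower number from compound 1 to compound 3 (0.71 log units; beyond the scatter); the comparison a 1.0-fold higher number from compound 2 to compound 3 (0.00 log units; within the scatter) is within the scatter, so compound 2 and compound 3 are not separated on this read-out.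

Compound 4 `CSCCSc1nc(NCc2ccc(-c3ccccn3)cc2)c2[nH]nc(C(C)C)c2n1` has not yet been measured in this assay. Against compound 1 the change is 2-(methylsulfanyl)ethyl in place of 1-(hydroxymethyl)-2-methylpropyl on a sulfur. Both measured steps from compound 1 bear on this one, since each also exchanges the group on that sulfur, and each gave a modest drop beyond the scatter. Neither earlier replacement carried a sulfur, however, and both kept a hydroxy-bearing group, which the entering 2-(methylsulfanyl)ethyl group does not; the direction is therefore not secured. Compound 4 is expected to show a step of about a 2.2-fold lower number from compound 1 to compound 4 (0.34 log units; beyond the scatter), while the range allows no change beyond the scatter. The estimate for compound 4 in this assay is 450 nM, between 130 nM and 1600 nM.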

Compound 4, concentration for 50% growth inhibition: 975 nM
The estimate for compound 4 lay 2.2-fold (0.34 log units) below the measured number; measured number inside the range.
By their numbers in this assay, from the lowest: compounds 2 and 3 (each within the scatter of the next); then compounds 4 and 1 (each within the scatter of the next).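

In this assay, 2-(methylsulfanyl)ethyl and 1-(hydroxymethyl)-2-methylpropyl on the sulfur are not separated, with a 1.0-fold lower number from compound 1 to compound 4 (0.00 log units; within the scatter), so the hydroxy group that leaves and the difference in heavy atoms bring no readable shift in this pair. The earlier drops from compound 1 therefore do not follow from removing the 1-(hydroxymethyl)-2-methylpropyl group as such: the position still separates open-chain groups, with a 5.1-fold higher number from compound 3 to compound 4 (0.71 log units; beyond the scatter) and a 5.1-fold higher number from compound 2 to compound 4 (0.71 log units; beyond the scatter). A hydroxy group alone does not sort the series either, since compound 1 and compound 2 both carry one and their numbers lie beyond the scatter of each other, while compound 3 shares the low end with compound 2 through a carbamoylmethyl group.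

The data shown offer no measurement that accounts for these differences at the sulfur. Still open, from the compounds shown here alone, is whether the sulfur inside the 2-(methylsulfanyl)ethyl chain matters, which a plain butyl chain would test, and whether a 2-aminoethyl or carboxymethyl group on the same sulfur would fall with compound 2 and compound 3 or with compound 1 and compound 4.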